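The compounds below may be only part of what the source reports. "The series", "measured", "known", "first", "only" and "open" are said of these compounds alone.

Measured in an assay on cells for inhibition of HSP60/HSP10 (Homo sapiens), with a stated time of 60 min; on this read-out higher numbers stand for weaker inhibition and lower numbers for stronger inhibition:

Compound 1 `O=S(=O)(Nc1ccc(-c2nc3ccccc3o2)cc1)c1cccc(F)c1`: 71000 nM
Compound 2 `O=S(=O)(Nc1ccc(-c2nc3ccccc3o2)cc1)c1ccc(Cl)s1`: 31000 nM

Compound 2 gives the lower of the two numbers. Among the measured compounds shown here, the single step seen so far is a 2.3-fold lower number from compound 1 to compound 2 (0.36 log units; beyond the scatter), a modest change that exchanges one aryl group for another on the sulfonyl sulfur while the shared core is kept.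

Compound 3 `O=S(=O)(Nc1ccc(-c2nc3ccccc3o2)cc1)c1ccccc1Cl` has not been measured. It differs from compound 2 as follows: 2-chlorophenyl in place of 5-chlorothiophen-2-yl on a sulfonyl sulfur. This change bears only on the step above, and in reverse sense: a six-membered carbon-only ring returns in place of the five-membered ring with one hetero atom, now carrying chlorine rather than fluorine. For the measured compounds named here, with one step of modest size as the only guide, compound 3 is expected to sit between compound 2 and compound 1, and the step of a 1.6-fold higher number from compound 2 to compound 3 (0.21 log units; within the scatter) is estimated to be modest at most, possibly within the scatter. The estimate for compound 3 in this assay is 50000 nM, with a range from 20000 nM to 120000 nM.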

Compound 3, half-maximal inhibitory concentration: > 100000 nM
Compound 3: no number, only a limit (the forecaster's own chance of this, stated with the estimate: 15%); middle value at least 2.0-fold (0.30 log units) from the limit.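

In this assay compound 3 gives > 100000 nM as a limit of the assay and not a number. On the sulfonyl sulfur, a chlorine on the aryl ring does not by itself keep the lower number of compound 2: 2-chlorophenyl in place of 5-chlorothiophen-2-yl gives an at least 3.2-fold higher number from compound 2 to compound 3 (0.50 log units; beyond the scatter) and so the ring and the placing of its chlorine count at this position, not the mere presence of chlorine. Against 3-fluorophenyl the reading is weaker, with an at least 1.4-fold higher number from compound 1 to compound 3 (0.14 log units; that floor lies within the scatter) as all that can be said, and these two aryl groups are not separated.

From the compounds shown here alone, how much the ring and the chlorine each contribute stays open, since the change to compound 3 alters both together. Also open, going by these compounds, is whether another kind of group on the ring, such as an amine or a carboxylic acid, would bring the number below that of compound 2.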